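The source may report more compounds than this note shows. Statements on the series, on what has been measured and on what is new or still open speak of the compounds shown alone.

Measured compounds: compound 1 `COc1ccc(N(CC(=O)NCCC[Te]c2ccccc2)C(=O)c2ccccc2)cc1` with 27000 nM; compound 2 `CC(C)(C)OC(=O)NCC(=O)OCC(=O)NCCC[Te]c1ccccc1` with 300 nM; compound 3 `COc1ccc(N(CC(=O)NCCC[Te]c2ccccc2)C(=O)/C=C/c2ccccc2)cc1` with 2000 nM.

In a functional assay on MCF7 cells (Homo sapiens) for cytotoxicity, read by MTT assay, with a stated time of 24 h (a lower number here means a stronger inhibitor, a higher number a weaker inhibitor), compound 1 gives the highest of the three numbers. Its nearest neighbour is compound 3, reached by a 14-fold lower number from compound 1 to compound 3 (1.13 log units; beyond the scatter); compound 2 lies further still, with a markedly lower number than compound 1.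

Compound 4 `COc1ccc(N(CC(=O)NCCCSc2ccccc2)C(=O)c2ccccc2)cc1` differs from compound 1 in one place: a group of 7 heavy atoms (6 carbon, 1 sulfur; one six-membered aromatic ring of carbon only) in place of a group of 7 heavy atoms (6 carbon, 1 tellurium; one six-membered aromatic ring of carbon only), on a saturated chain carbon, three bonds along the chain from an amide-type nitrogen. Among the measured compounds shown here, none of the measured steps bears on this change. For the measured compounds named here, the single step from compound 1 to compound 3 concerns the group on the carbonyl carbon, not the atom at the end of the chain, and compound 2 differs from compound 1 in several places at once, so only its value can be compared, not a single change. Going by the values given here, no measured pair replaces tellurium by sulfur.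

The expectation for compound 4 therefore rests on the value of compound 1 alone and must be held wide. Compound 4 is estimated at 50000 nM, with a range from 12000 nM to 200000 nM. The step this estimate means, a 1.9-fold higher number from compound 1 to compound 4 (0.27 log units; within the scatter), is expected to be modest and toward a higher number, but it is not anchored by any measured step.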

Compound 4, half-maximal inhibitory concentration in the MCF7 assay: >= 100000 nM
Compound 4 was reported as a limit; the forecaster's own chance of this, stated with the estimate: 25%; middle value at least 2.0-fold (0.30 log units) from the limit.
By their numbers in the MCF7 assay, from the lowest: compound 2; then compound 3; then compound 1. At a limit, above all of these: compound 4.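

In the MCF7 assay, sulfur in place of tellurium, on a saturated chain carbon, gives an at least 3.7-fold higher number from compound 1 to compound 4 (0.56 log units; beyond the scatter), the only step shown that touches this position, and it shows that the tellurium atom matters there as much as the carbonyl group does elsewhere in the molecule. For compound 4 this step rests on a limit of the assay, not on a number. In a physicochemical assay for lipophilicity, read by HPLC, measured as octanol-water partition (on this read-out lower numbers stand for lower lipophilicity and higher numbers for higher lipophilicity), compound 1 gives 1.72 and compound 4 gives 3.1, so the compound with tellurium has both the lower partition coefficient and the lower number in the MCF7 assay.

Sulfur in place of tellurium is shown only on the core of compound 1, so whether the step carries over to compound 2 or compound 3 stays open. Nor do the compounds shown tell what selenium at this position, or a longer chain leading to the tellurium, would do.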